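The source may report more compounds than this note shows. Statements on the series, on what has been measured and on what is new or still open speak of the compounds shown alone.

Compound 1 `CC(=O)OC(C)n1cnc2c(Cl)nc(I)nc21` and compound 2 `CC(O)n1cnc2c(Cl)nc(I)nc21` share one core, while compound 3 `CC(=O)OC(C)n1cnc2c(S)nc(F)nc21` and compound 4 `CC(O)n1cnc2c(S)nc(F)nc21` share another; how the two cores differ is not broken down here. All four belong to the same series and were studied in a functional assay on FM3A cells (Homo sapiens) for inhibition, with FM3A (Mus musculus) as the target; on this read-out lower numbers stand for stronger inhibition and higher numbers for weaker inhibition. In this assay compound 1 gives 47000 nM, compound 2 gives 479000 nM, and compound 3 gives 368000 nM. Compound 3 and compound 2 therefore sit close together, whereas compound 1 sits well apart from both.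

The change from compound 1 to compound 2 is hydrogen in place of acetyl on an oxygen on a saturated carbon and it produced a 10-fold higher number from compound 1 to compound 2 (1.01 log units; beyond the scatter), a clear loss of inhibition. The same change is made from compound 3 to compound 4: hydrogen in place of acetyl on an oxygen on a saturated carbon The place of the change is the same in both pairs, so this is the same change seen a second time, now on a different core.

Because the first pair moved by a 10-fold higher number from compound 1 to compound 2 (1.01 log units; beyond the scatter), the step from compound 3 to compound 4 is expected to run in the same direction and to be of a roughly similar size, a 4.9-fold higher number from compound 3 to compound 4 (0.69 log units; beyond the scatter). Compound 3 already gives a high number, so the result for compound 4 may fall where this assay can only report a limit. Compound 4 is expected to give about 1800000 nM, most likely between 500000 nM and 6000000 nM.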

Compound 4, half-maximal inhibitory concentration: > 500000 nM
Compound 4: only a limit was reported; the forecaster's own chance of this, stated with the estimate: 35%; the middle value is on the limit's open side.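

In this assay compound 4 gives > 500000 nM, which is a limit of the assay and not a number. Going from acetoxy to hydroxy on this second core gives an at least 1.3-fold higher number from compound 3 to compound 4 (0.13 log units; that floor lies within the scatter), so the result does not run against the direction seen on the first core, but this floor alone does not establish a loss of inhibition on the core of compound 3. The two pairs therefore fit a change that may carry over from one core to the other, without showing that it does or that its size stays the same: the same change on two cores in this assay, a 10-fold higher number (1.01 log units; beyond the scatter) from compound 1 to compound 2 and an at least 1.3-fold higher number (0.13 log units; that floor lies within the scatter) from compound 3 to compound 4; the limit leaves it open whether they differ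

The compounds shown hold only acetoxy and hydroxy at this place on each of two cores, which leaves open how a longer chain on the ester, or an amine in place of the acetoxy, would read in this assay. On these data alone, it also remains open how far the true value of compound 4 lies past its limit, and a firm comparison of the two steps would need an actual number for that compound.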